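A few compounds are considered here, and "the series" means these few. Any claim that something is new, unique, unknown or untested is made for them only; others in the source may bear on it.

In a toxicity assay on HepG2 cells (Homo sapiens) for inhibition, read by CellTiter-Glo, with a stated time of 48 h (a lower number here means a stronger inhibitor, a higher number a weaker inhibitor), compound 2 `COc1ccc2nc(C)cc(OCC(=O)Nc3cc(C)ccc3OC)c2c1` gives only a limit, > 100000 nM. Among the measured compounds shown here, compound 1 `COc1ccc2nc(C)cc(OCC(=O)Nc3cccc(C)c3)c2c1` gives 39800 nM in this assay, and the step of an at least 2.5-fold higher number from compound 1 to compound 2 (0.40 log units; beyond the scatter) is the sole measured change, resting on (the limit of > 100000 nM in this assay, at which 1 of the 2 values shown sits). Compound 3 `COc1ccc2nc(C)cc(OCC(=O)Nc3ccc(Cl)cc3Cl)c2c1` differs from compound 2 by 2,4-dichlorophenyl in place of 2-methoxy-5-methylphenyl on an amide-type nitrogen. For the measured compounds named here, no measured step covers chlorine on the aryl amide, so the expectation for compound 3 can only be anchored loosely on compound 1, which gives 39800 nM in this assay. Compound 3 is therefore expected to sit near 50000 nM, between 20000 nM and 150000 nM, an expected step of an at least 2.0-fold lower number from compound 2 to compound 3 (0.30 log units; that floor lies within the scatter) in this assay.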

Compound 3, half-maximal inhibitory concentration: > 100000 nM
Compound 3 was reported as a limit (the forecaster's own chance of this, stated with the estimate: 40%); middle value at least 2.0-fold (0.30 log units) away from the limit.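

On the amide-type nitrogen, 2,4-dichlorophenyl in place of 3-methylphenyl gives an at least 2.5-fold higher number from compound 1 to compound 3 (0.40 log units; beyond the scatter) in this assay, so a higher number here does not depend on the methoxy group of compound 2. Compound 2 and compound 3 both stand as limits, not numbers, so the step between them cannot be read, and the series now gathers at one ceiling: the limit of > 100000 nM in this assay, at which 2 of the 3 values shown sit.

From the compounds shown here alone, the true order of compound 2 and compound 3 stays open. So does whether a carboxylic acid or an amine on the aryl group would give a lower number than compound 1.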